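The source may report more compounds than this note shows. Statements on the series, on what has been measured and on what is new or still open speak of the compounds shown alone.

Measured in a functional assay with Oryctolagus cuniculus as the target; a higher number here means a weaker inhibitor, a lower number a stronger inhibitor:
- Compound 1 `COc1ccc(-c2nc(CNC(=O)C3=NNC(=O)CC3)sc2-c2ccc(OC)cc2)cc1`: 55 nM
- Compound 2 `COc1ccc(-c2nc(C(=O)N3CCCCC3)sc2-c2ccc(OC)cc2)cc1`: > 1000 nM (a limit)

Compound 2 gives no number in this assay, only the limit > 1000 nM. Compound 3 `COc1ccc(-c2nc(CCC(=O)O)sc2-c2ccc(OC)cc2)cc1` keeps both 4-methoxyphenyl groups of compound 2, and the change is 2-carboxyethyl in place of (piperidin-1-yl)carbonyl on an aromatic carbon. Among the measured compounds shown here, no measured step isolates this change, so any expectation is tentative. A modest move towards a stronger inhibitor is expected, and another limit would be no surprise. The estimated change is an at least 1.6-fold lower number from compound 2 to compound 3 (0.22 log units; that floor lies within the scatter). For compound 3 the estimated value is 600 nM, with an expected range of 80 nM to 3000 nM.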

Compound 3, half-maximal inhibitory concentration: < 100 nM
Compound 3: a limit, no number; the forecaster's own chance of this, stated with the estimate: 45%; middle value at least 6.0-fold (0.77 log units) away from the limit.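

In this assay, 2-carboxyethyl in place of (piperidin-1-yl)carbonyl on this aromatic carbon gives an at least 10-fold lower number from compound 2 to compound 3 (1.00 log units; beyond the scatter). Among the compounds shown here, this is the first step read at this position, and it shows that the group here alone can shift the number beyond the scatter while both 4-methoxyphenyl groups stay in place. Compound 3 gives a limit, not a number: the limit of < 100 nM in this assay, at which 1 of the 3 values shown sits.

Going by these compounds, the step from compound 1 cannot be read, so how compound 3 compares with it stays open. Also open, on these data alone, is whether an amine or a methyl ester at the end of the same chain, or a longer chain ending in a carboxylic acid, would give a similar result.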